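A Phenyl Swap on Sulfur

The source may hold more compounds than are shown below. What is called first, only, known or untested is meant among the compounds shown, and "the series" means these compounds.

In a functional assay on HCC827 cells (Homo sapiens) for antiproliferative activity, read by MTT assay, with a stated time of 72 h (a higher number here means a weaker inhibitor, a lower number a stronger inhibitor), compound 1 `CC(C)n1c(Sc2ccccc2)nc2cnc(Nc3ccc(N4CCN(C)CC4)cc3)nc21` gives 290 nM as its reading. Compound 2 `CN1CCN(c2ccc(Nc3ncc4nc(SCc5cccnc5)n(C5CC5)c4n3)cc2)CC1` gives 8830 nM and so holds the higher of the two numbers, which makes it the weaker inhibitor of the pair by a gap beyond the usual scatter.

Compound 3 `CN1CCN(c2ccc(Nc3ncc4nc(Sc5ccccc5)n(C5CC5)c4n3)cc2)CC1` has not yet been measured. It differs from compound 2 in one place, with phenyl in place of (pyridin-3-yl)methyl on a sulfur, and phenyl in place of (pyridin-3-yl)methyl on a sulfur gives the full count of that change. Among the measured compounds shown here, no measured pair shows this change alone, so its size can only be judged indirectly. For the measured compounds named here, the one guide is compound 1 at 290 nM on the same scale, which also carries phenyl on a sulfur but is not otherwise identical to compound 3. A large step in this assay is therefore expected, beyond the scatter, towards a lower number and a stronger inhibitor. The estimated change is a 20-fold lower number from compound 2 to compound 3 (1.29 log units; beyond the scatter) in size, though this remains uncertain. For compound 3 the estimated value is 450 nM within an expected range from 130 nM to 1800 nM in this test.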

Compound 3, half-maximal inhibitory concentration: 305 nM
For compound 3 the middle estimate is 1.5-fold (0.17 log units) above the measured one, within the range that was stated.
By their numbers in this assay, from the lowest: compounds 1 and 3 (each within the scatter of the next); then compound 2.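

In this assay, the change from (pyridin-3-yl)methyl to phenyl on a sulfur whose other neighbour is an aromatic carbon can now be read on its own, and it gives a 29-fold lower number from compound 2 to compound 3 (1.46 log units; beyond the scatter), a large step that shows how strongly the reading depends on the group at this position. The same result also isolates a second change: cyclopropyl in place of isopropyl on an aromatic nitrogen gives a 1.1-fold higher number from compound 1 to compound 3 (0.02 log units; within the scatter), which is within the scatter, so with phenyl on the sulfur this swap leaves no visible mark on the reading. No measured information here explains why the group on the sulfur matters so much.

The large step combines two differences, the nitrogen in the aromatic ring and the methyl link to the sulfur, and the compounds shown cannot separate them. Benzyl or pyridin-3-yl on the sulfur would each carry only one of these differences, while an amine in place of the sulfur would test whether phenyl depends on the sulfur at all.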